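Swapping a Phenyl for Methoxy in a Cell Growth Inhibitor

The compounds below may be only part of what the source reports. "The series", "measured", "known", "first", "only" and "open" are said of these compounds alone.

Compound 1 `CC(=O)c1cccc(Nc2ccnc(SCC(=O)c3ccc(-c4ccccc4)cc3)n2)c1`: 14%
Compound 2 `CC(=O)c1ccc(Nc2ccnc(SCC(=O)c3ccc(Cl)cc3)n2)cc1`: 27%

In a functional assay on MDA-MB-468 cells (Homo sapiens) for inhibition, read by sulforhodamine B assay, with a stated time of 48 h, tested at 10 uM (on this read-out higher numbers stand for more inhibition of growth at the one concentration tested and lower numbers for less inhibition of growth), compound 1 gives 14%, the lower of the two numbers measured. Compound 2 gives 27%, which lies beyond the usual scatter from the value of compound 1. Compound 3 `COc1ccc(C(=O)CSc2nccc(Nc3cccc(C(C)=O)c3)n2)cc1` differs from compound 1 by methoxy in place of phenyl on an aromatic carbon. Among the measured compounds shown here, no pair of measured compounds isolates this change, so its direction is unknown, and a small step in either direction, close to the scatter, is expected. Compound 3 is therefore expected to give 20%, with a range from 5% to 40%. For compound 3 this estimate means an expected step of a number 6 percentage points higher from compound 1 to compound 3 (within the scatter).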

Compound 3, percent growth inhibition at one concentration: 34%
Compound 3: the middle estimate sits 14 percentage points below what was measured, within the range that was stated.
By their numbers in this assay, from the lowest: compound 1; then compounds 2 and 3 (each within the scatter of the next).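

On the aromatic carbon para to a large group, the phenyl is not required for growth inhibition: in this assay, the smaller methoxy gives a number 20 percentage points higher from compound 1 to compound 3 (beyond the scatter). Among the compounds shown here, this position therefore responds to the group placed on it, which no earlier pair of compounds could show. Nothing available explains the gain.

From the compounds shown here alone, it remains open whether the gain follows from losing the phenyl ring or from adding the methoxy oxygen. A plain hydrogen, a hydroxyl, an amine or a longer ethoxy chain at this position would help separate those two readings.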